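This account rests on a few compounds, and the source may have more. Where it says the series, first, only, none or still open, it means among the compounds named here.

Compound 1 `CCCCCCCOc1ccc(CCC(N)(CO)C(C)C)cc1`: 4.5 mg/kg
Compound 2 `CCCCCCCOc1ccc(CCC(N)(CO)CCC)cc1`: 7.3 mg/kg

Compound 3 `CCCCCCCOc1ccc(CC[C@](N)(CO)CCC)cc1` has not yet been measured in a functional assay on the whole organism (spleen, spleen) with Rattus norvegicus as the target; on this read-out higher numbers stand for an effect only at larger amounts of compound and lower numbers for an effect already at smaller amounts. Going by the values given here, on the two numbers so far, compound 2 stands highest, and its only neighbour is compound 1; the one measured step, a 1.6-fold higher number from compound 1 to compound 2 (0.21 log units; within the scatter), concerns a propyl in place of isopropyl and lies within the scatter. The change now in question is different in kind: the two compounds have the same atoms and bonds; at least one stereo element is drawn with a configuration in one of them and without one in the other: 1 of 1 stereo elements differ; a stereocentre at a saturated chain carbon is drawn without a configuration in compound 2 and S in compound 3. Among the compounds with values here, no measured step touches a stereocentre, so the data give no direction for this change. Compound 3 is therefore expected to stay close to compound 2, with a step of a 1.5-fold lower number from compound 2 to compound 3 (0.16 log units; within the scatter), and the estimate for compound 3 is 5 mg/kg, with a range of 2 mg/kg to 15 mg/kg.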

Compound 3, dose for 50% inhibition: > 10 mg/kg
Compound 3 was reported as a limit; the forecaster's own chance of this, stated with the estimate: 5%; middle value at least 2.0-fold (0.30 log units) from the limit.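

In this assay, compound 3 gives > 10 mg/kg, which is a limit of the assay and not a number. Going by these compounds alone, the stereo change brings an at least 1.3-fold higher number from compound 2 to compound 3 (0.13 log units; that floor lies within the scatter), so the size of the effect of drawing the S configuration stays undetermined, while an at least 2.2-fold higher number from compound 1 to compound 3 (0.34 log units; beyond the scatter) is the first step in this short series to pass beyond the scatter. This comparison with the undefined drawing rests on one difference only: the fact that one of compounds 2 and 3 is drawn with a defined configuration and the other without, at the place where they differ

The compounds shown leave open how the R configuration at this stereocentre would read. They also leave open whether an ethyl or a butyl in place of the propyl would shift the dose.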